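This account rests on a few compounds, and the source may have more. Where it says the series, first, only, none or still open, it means among the compounds named here.

Compound 1 `O=C(O)CCCCCC[C@@H]1[C@@H](CC[C@@H](O)CCc2ccc(F)cc2)[C@H](O)C[C@@H]1O` and compound 2 `COc1ccc(CC[C@H](O)CC[C@@H]2[C@@H](CCCCCCC(=O)O)[C@@H](O)C[C@H]2O)cc1` share the same core and differ only in the group carried on the aromatic ring. In an in vitro assay on CHO-KI cells for displacement of a labelled ligand from prostaglandin E2 receptor EP1 subtype (Homo sapiens) (a lower number here means a stronger inhibitor, a higher number a weaker inhibitor), compound 1 gives 3450 nM. For compound 2 this assay reports only a limit, > 10000 nM. The step of an at least 2.8-fold higher number from compound 1 to compound 2 (0.46 log units; beyond the scatter) is therefore known only as a floor, which rests on (the limit of > 10000 nM in this assay, at which 1 of the 2 values shown sits). Compound 2 thus stands at the weak end of the two values shown, without an exact number of its own.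

Compound 3 `CCc1cccc(CC[C@H](O)CC[C@@H]2[C@@H](CCCCCCC(=O)O)[C@@H](O)C[C@H]2O)c1` differs from compound 2 by 3-ethylphenyl in place of 4-methoxyphenyl on a saturated chain carbon, three bonds along the chain from an oxygen on a saturated carbon. Among the compounds with values here, no measured pair sets an ethyl-bearing ring against a methoxy-bearing one, so the only step that bears on this change is an at least 2.8-fold higher number from compound 1 to compound 2 (0.46 log units; beyond the scatter), which shows that swapping one small group on that ring can shift the number beyond the scatter. Because compound 2 is known only as the limit > 10000 nM, the size of the step to compound 3 cannot be fixed in either direction. Compound 3 is expected to come in at 7000 nM, within 1500 nM to 30000 nM, meaning an estimated step of an at least 1.4-fold lower number from compound 2 to compound 3 (0.15 log units; that floor lies within the scatter), with a real chance that only a limit is again reported.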

Compound 3, half-maximal inhibitory concentration: > 10000 nM
Compound 3 ended at the assay's limit (the forecaster's own chance of this, stated with the estimate: 45%); at least 1.4-fold (0.15 log units) between middle value and limit.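

Compound 3 adds a second ring to the comparison with compound 1: 3-ethylphenyl in place of 4-fluorophenyl also worsens the result in this assay, with an at least 2.8-fold higher number from compound 1 to compound 3 (0.46 log units; beyond the scatter). The weakening at this position is therefore not confined to the 4-methoxyphenyl ring of compound 2, and it appears with a ring that carries no oxygen, since 3-ethylphenyl is made of carbon only. Among the three compounds shown, only compound 1 with its 4-fluorophenyl ring has an exact number, but the step from compound 2 to compound 3 cannot be read, because each of the two is known only as a limit: the limit of > 10000 nM in this assay, at which 2 of the 3 values shown sit.

Going by these compounds, the order of compound 2 and compound 3 therefore stays open, as does how far either lies from compound 1 beyond the floor already given. On these data alone, the names 4-fluorophenyl and 3-ethylphenyl differ in both the group and its place on the ring, so the effect of each alone remains unknown, and it is equally open how a plain phenyl ring or a chloro-bearing ring would read.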